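The source may hold more compounds than are shown below. What is called first, only, known or untested is meant among the compounds shown, and "the series" means these compounds.

Compound 1 `CC1(C)CC(NC(=S)Nc2cccc(C#N)c2)c2cc(Cl)ccc2O1` gives 10000 nM in a functional assay on T98G cells (Homo sapiens) for inhibition, read by MTT assay, with a stated time of 72 h (a higher number here means a weaker inhibitor, a lower number a stronger inhibitor), the highest of the two numbers recorded there. Compound 2 `CC1(C)CC(NC(=S)Nc2cccc([N+](=O)[O-])c2)c2cc(Cl)ccc2O1` gives 4000 nM in this assay. Within the data shown here, the only step known, a 2.5-fold lower number from compound 1 to compound 2 (0.40 log units; beyond the scatter), exchanges the group itself rather than moving it, so it bears only loosely on the present change. Compound 3 `CC1(C)CC(NC(=S)Nc2ccc(C#N)cc2)c2cc(Cl)ccc2O1` keeps the shared core and differs from compound 1 by 4-cyanophenyl in place of 3-cyanophenyl on an amide-type nitrogen. Among the measured compounds shown here, with no measured precedent for relocating the nitrile, the step of no change at the digits printed from compound 1 to compound 3 (within the scatter) for compound 3 is expected to stay within the scatter. Compound 3 is thus estimated at 10000 nM, within a range of 4000 nM to 25000 nM.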

Compound 3, half-maximal inhibitory concentration: 10000 nM
Beside the measured number, compound 3's estimate shows no gap at the digits printed; low and high end bracket the measured number.
By their numbers in this assay, from the lowest: compound 2; then compounds 1 and 3 (each within the scatter of the next).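

Moving the nitrile leaves the number in place in this assay: the change to 4-cyanophenyl from 3-cyanophenyl on the amide-type nitrogen gives no change at the digits printed from compound 1 to compound 3 (within the scatter). For this pair, the location of the nitrile therefore does not register in the read-out, whereas exchanging the group gave a 2.5-fold lower number from compound 1 to compound 2 (0.40 log units; beyond the scatter). No measurement at hand accounts for this result. On these data alone, whether the nitro group of compound 2 would tolerate the same relocation remains open, as does the effect of an amine or a carboxylic acid on this aromatic ring.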